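Adding a second fluorine to a cinnamoyl sulfonamide

A few compounds are considered here, and "the series" means these few. Any claim that something is new, unique, unknown or untested is made for them only; others in the source may bear on it.

Three compounds share one core. Compound 1 `O=C(/C=C/c1ccccc1)NS(=O)(=O)c1ccccc1` carries no fluorine; compound 2 `O=C(/C=C/c1ccccc1)NS(=O)(=O)c1ccc(F)cc1` has a fluorine on the sulfonyl-bearing ring; compound 3 `O=C(/C=C/c1ccc(F)cc1)NS(=O)(=O)c1ccccc1` has a fluorine on the other ring. In a functional assay on B16-F10 cells (Mus musculus) for antiproliferative activity, read by ELISA and MTT assay, with a stated time of 48 h (on this read-out higher numbers stand for weaker inhibition and lower numbers for stronger inhibition), compound 1 gives 3.5 ug/mL, compound 2 gives 2.1 ug/mL and compound 3 gives 2.1 ug/mL. Compound 3 therefore shares its number with compound 2 at the digits shown, and the steps of a 1.7-fold lower number from compound 1 to compound 2 (0.22 log units; within the scatter) and a 1.7-fold lower number from compound 1 to compound 3 (0.22 log units; within the scatter) both stay within the scatter.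

Compound 4 `O=C(/C=C/c1ccc(F)cc1)NS(=O)(=O)c1ccc(F)cc1` combines both fluorines. Relative to compound 3 the change is fluoro in place of hydrogen on an aromatic carbon, the same change that carried compound 1 to compound 2, read one bond further out as phenyl to 4-fluorophenyl. Within the data shown here, the only directly relevant step, a 1.7-fold lower number from compound 1 to compound 2 (0.22 log units; within the scatter), was small, so at most a similarly small shift, or none beyond the scatter, is expected in this assay for compound 4; the expected step is a 1.4-fold lower number from compound 3 to compound 4 (0.15 log units; within the scatter). Compound 4 is estimated at 1.5 ug/mL, in a range from 0.8 ug/mL to 3 ug/mL.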

Compound 4, half-maximal inhibitory concentration: 0.8 ug/mL
The estimate for compound 4 lay 1.9-fold (0.27 log units) above the measured number, and the stated range covers the measured number.
By their numbers in this assay, from the lowest: compound 4; then compounds 2, 3 and 1 (each within the scatter of the next).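

Fluoro in place of hydrogen gives a step beyond the scatter once the other ring already carries a fluorine: in this assay the change yields a 2.6-fold lower number from compound 3 to compound 4 (0.42 log units; beyond the scatter) and also a 2.6-fold lower number from compound 2 to compound 4 (0.42 log units; beyond the scatter). This does not show that the second fluorine counts for more than the first, as the steps on the ring bearing the sulfonyl group agree within the scatter: the same change on two cores in this assay, a 1.7-fold lower number (0.22 log units; within the scatter) from compound 1 to compound 2 and a 2.6-fold lower number (0.42 log units; beyond the scatter) from compound 3 to compound 4, 1.6-fold (0.20 log units) apart, within the scatter of two such steps. The steps on the other ring agree in the same way: the same change on two cores in this assay, a 1.7-fold lower number (0.22 log units; within the scatter) from compound 1 to compound 3 and a 2.6-fold lower number (0.42 log units; beyond the scatter) from compound 2 to compound 4, 1.6-fold (0.20 log units) apart, within the scatter of two such steps.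

The compounds shown hold only hydrogen or fluoro at these places, so it stays open whether the lower number belongs to fluoro itself or would also come with chloro, a methoxy group or an amine. As far as these compounds go, it also stays open how fluoro would behave at another place on either ring.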